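A few compounds are considered here, and "the series" means these few. Any claim that something is new, unique, unknown or untested is made for them only; others in the source may bear on it.

In a functional assay on NCI-H460 cells (Homo sapiens) for cytotoxicity (on this read-out lower numbers stand for stronger inhibition and higher numbers for weaker inhibition), compound 1 `Cc1ccc(NC(=O)[C@H](CCCCCC(=O)NO)NC(=O)[C@H]2CCC(=O)N2)cc1` gives 600 nM and compound 2 `Cc1cccc(NC(=O)CCCCCCC(=O)NO)c1` gives 800 nM so the two stand within the scatter of each other. Compound 3 `Cc1ccc(NC(=O)CCCCCCC(=O)NO)cc1` carries hydrogen in place of ((5-oxopyrrolidin-2-yl)carbonyl)amino on a saturated chain carbon bound to a carbonyl carbon and a saturated chain carbon. Going by the values given here, no measured pair shows this change on its own. Among the compounds with values here, with compound 2 at 800 nM as the only other reading, no step beyond the scatter is expected in this assay for this change. The expected step of a 1.3-fold higher number from compound 1 to compound 3 (0.12 log units; within the scatter) is therefore small. The estimate for compound 3 is 800 nM (350 nM to 1800 nM).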

Compound 3, half-maximal inhibitory concentration: 4100 nM
For compound 3 the middle estimate is 5.1-fold (0.71 log units) below the measured one, and the stated range ends below it.
By their numbers in this assay, from the lowest: compounds 1 and 2 (each within the scatter of the next); then compound 3.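

In this assay, hydrogen in place of ((5-oxopyrrolidin-2-yl)carbonyl)amino on this saturated chain carbon gives a 6.8-fold higher number from compound 1 to compound 3 (0.83 log units; beyond the scatter), a modest step beyond the scatter. Going by these compounds alone, this is the first reading of this change on its own, and it shows that the group on this carbon matters for the number in this assay. Nothing at hand explains the step. On these data alone, it remains open whether the five-membered ring is needed, or whether a plain amine or an acetylamino group on the same carbon would keep the lower number.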